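The compounds below may be only part of what the source reports. "The series", "measured", "known", "first", "only" and "open" are said of these compounds alone.

In a functional assay on PC-3 cells (Homo sapiens) for cytotoxicity, read by MTT assay, with a stated time of 72 h (a lower number here means a stronger inhibitor, a higher number a weaker inhibitor), compound 1 (`O=C(N/N=C/c1ccc(F)cc1)Nc1cc2c(Nc3ccc(F)c(Cl)c3)ncnc2cc1O[C@H]1CCOC1`) gives "not active" (no number reported) and so provides no number. For the measured compounds named here, in the same measurement compound 2 (`COc1cc2ncnc(Nc3ccc(F)c(Cl)c3)c2cc1NC(=O)N/N=C/c1ccc(F)cc1`) gives 36500 nM as the only number available, which leaves it with no numerical neighbour to be ranked against. Compound 3 (`COc1cc2ncnc(Nc3ccc(F)c(Cl)c3)c2cc1NC(=O)N/N=C/c1cccc(Cl)c1Cl`) differs from compound 2 in one place, with 2,3-dichlorophenyl in place of 4-fluorophenyl on a carbon with a double bond to nitrogen as the count: 2,3-dichlorophenyl stands in place of 4-fluorophenyl on a carbon with a double bond to nitrogen. Going by the values given here, no measured step between compounds bears on this change, so the size of any shift in this assay remains a matter of expectation. The estimated 1.7-fold lower number from compound 2 to compound 3 (0.22 log units; within the scatter) is expected to stay within the usual scatter, with a slight lean towards stronger inhibition. For compound 3 the estimated value is 22000 nM with an expected range from 6000 nM to 70000 nM in this measurement.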

Compound 3, half-maximal inhibitory concentration: 24400 nM
Compound 3: middle estimate off by 1.1-fold (0.04 log units), on the low side; the measured number falls inside the stated range.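

In this assay, the exchange on the carbon with a double bond to nitrogen gives the first readable step, a 1.5-fold lower number from compound 2 to compound 3 (0.17 log units; within the scatter), and that step lies within the scatter. Replacing 4-fluorophenyl with 2,3-dichlorophenyl therefore leaves the two compounds indistinguishable in this measurement, so this position accepts this particular change without a readable shift. Nothing measured here explains this result or links it to any property of either group.

Both groups at this position are halogen-bearing aromatic rings of carbon only, so the compounds shown leave open whether an amine, a carboxylic acid or a longer alkyl chain in that place would give a step beyond the scatter. As far as these compounds go, compound 1 has no number, so any step involving it cannot be read, and what its different group on the shared core does in this measurement also stays open.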